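This account rests on a few compounds, and the source may have more. Where it says the series, first, only, none or still open, it means among the compounds named here.

- compound 1 `O=C(CC(c1ccc(Cl)cc1)C(C(=O)Nc1ccccn1)C(=O)Nc1ccccn1)c1ccccc1`: 18900 nM
- compound 2 `O=C(CC(c1c(Cl)cccc1Cl)C(C(=O)Nc1ccccn1)C(=O)Nc1ccccn1)c1ccccc1`: 27400 nM
- compound 3 `O=C(CC(c1ccc(Cl)cc1)C(C(=O)Nc1ccccn1)C(=O)Nc1ccccn1)c1ccc2ccccc2c1`: "not active" (no number reported)

Going by the values given here, in a functional assay on NCI-H460 cells (Homo sapiens) for inhibition, read by MTT assay, with a stated time of 48 h (on this read-out lower numbers stand for stronger inhibition and higher numbers for weaker inhibition), compound 1 gives 18900 nM, and only one other compound has a number to compare with it. Compound 4 `Cc1cc(C)c(C(CC(=O)c2ccccc2)C(C(=O)Nc2ccccn2)C(=O)Nc2ccccn2)c(C)c1` has not been measured and differs from compound 1 as follows: 2,4,6-trimethylphenyl in place of 4-chlorophenyl on a saturated chain carbon bound to two saturated chain carbons. Among the compounds with values here, one measured step bears on this change, as it replaces the same group on the saturated chain carbon: a 1.4-fold higher number from compound 1 to compound 2 (0.16 log units; within the scatter). Within the data shown here, a single step is thin evidence, but with compound 2 as the only guide, no change beyond the scatter is expected. The expected step is a 1.2-fold higher number from compound 1 to compound 4 (0.07 log units; within the scatter). For compound 4 the estimated value is 22000 nM, with an expected range from 10000 nM to 50000 nM.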

Compound 4, half-maximal inhibitory concentration: 23200 nM
Compound 4: middle estimate off by 1.1-fold (0.02 log units), on the low side, within the range that was stated.
By their numbers in this assay, from the lowest: compounds 1, 4 and 2 (each within the scatter of the next).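

In this assay the 2,4,6-trimethylphenyl group gives a 1.2-fold higher number from compound 1 to compound 4 (0.09 log units; within the scatter) and a 1.2-fold lower number from compound 2 to compound 4 (0.07 log units; within the scatter) at this place on the saturated chain carbon. Among these three compounds, then, a phenyl ring carrying methyl groups and no chlorine stays level with both chlorinated rings, which the two chlorinated compounds alone could not show. No measurement at hand accounts for this result. The compounds shown leave open whether a phenyl ring bearing an amine or a carboxylic acid at this place would move the number beyond the scatter. They also leave open what a longer chain in place of the ring would do.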